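Alkyne series: replacing the aryl end with chloropropyl

The source may hold more compounds than are shown below. What is called first, only, known or untested is meant among the compounds shown, and "the series" means these compounds.

Measured so far:
- compound 1, `O=c1[nH]c(=O)n(CCC(CO)CO)cc1C#Cc1ccc(Br)cc1`, in a functional assay on HeLa cells (Homo sapiens) for antiproliferative activity, read by MTT assay, with a stated time of 72 h (on this read-out lower numbers stand for stronger inhibition and higher numbers for weaker inhibition), gives 67700 nM
- compound 2, `CCCCCc1ccc(C#Cc2cn(CCC(CO)CO)c(=O)[nH]c2=O)cc1`, in this assay gives 48200 nM

Going by the values given here, compound 1 holds the higher of the two numbers; the sole measured step, a 1.4-fold lower number from compound 1 to compound 2 (0.15 log units; within the scatter), lies within the scatter. Compound 3, `O=c1[nH]c(=O)n(CCC(CO)CO)cc1C#CCCCCl`, differs from compound 1 by 3-chloropropyl in place of 4-bromophenyl on a triple-bonded carbon. Among the compounds with values here, the one measured step concerns a substituent on an aromatic ring that here leaves altogether, so it bears only loosely on this change; it shows that variation at this end of the molecule gave no movement beyond the scatter. For compound 3 no step beyond the scatter is expected, a 1.2-fold higher number from compound 1 to compound 3 (0.07 log units; within the scatter). Compound 3 is therefore estimated at 80000 nM, range 30000 nM to 200000 nM.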

Compound 3, half-maximal inhibitory concentration: > 100000 nM
Compound 3: a limit, no number; the forecaster's own chance of this, stated with the estimate: 25%; at least 1.2-fold (0.09 log units) between middle value and limit.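

In this assay compound 3 gives > 100000 nM, which is a limit of the assay and not a number. The step is an at least 1.4-fold higher number from compound 1 to compound 3 (0.16 log units; that floor lies within the scatter), so the earlier pair, which kept the aromatic ring, did not show that 3-chloropropyl on this triple-bonded carbon would leave the number no lower, although the floor alone does not establish a loss. The reading of this result rests on one point: the limit of > 100000 nM in this assay, at which 1 of the 3 values shown sits.

Whether compound 3 truly differs from compound 1 beyond the scatter remains undecided. Also open, from the compounds shown here alone, is how an amine or a carboxylic acid at the end of a longer chain on this triple-bonded carbon would read in this assay.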